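The source may hold more compounds than are shown below. What is called first, only, known or untested is meant among the compounds shown, and "the series" means these compounds.

Measured in a functional assay on MCF7 cells (Homo sapiens) for cytotoxicity, read by MTT assay, with a stated time of 48 h; on this read-out higher numbers stand for weaker inhibition and lower numbers for stronger inhibition:

- compound 1 `CCN(CC)C(=S)SC(CC(=O)c1ccccc1)c1ccc(F)cc1`: 700 nM
- compound 2 `CCN(CC)C(=S)SC(CC(=O)c1ccc(Br)cc1)c1ccc(OC)cc1`: 5000 nM

Of these two, compound 2 stands highest at 5000 nM, and the gap down to compound 1 at 700 nM lies beyond the scatter. Compound 3 `CCN(CC)C(=S)SC(CC(=O)c1ccc(Br)cc1)c1ccc(F)cc1` is compound 2 with fluoro in place of methoxy on an aromatic carbon, para to a large group (fluoro in place of methoxy on an aromatic carbon), the change from 4-methoxyphenyl to 4-fluorophenyl. Within the data shown here, no pair of measured compounds isolates a single change, so the evidence for this step is thin. Compound 1, at 700 nM, also carries 4-fluorophenyl, and this leads to the expectation of a moderate move towards stronger inhibition in this assay. The expected step of a 3.3-fold lower number from compound 2 to compound 3 (0.52 log units; beyond the scatter) points to a lower number. For compound 3 the estimate is 1500 nM, with an expected range of 500 nM to 4500 nM.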

Compound 3, half-maximal inhibitory concentration: 1000 nM
The estimate for compound 3 lay 1.5-fold (0.18 log units) above the measured number; the measured number falls inside the stated range.
By their numbers in this assay, from the lowest: compounds 1 and 3 (each within the scatter of the next); then compound 2.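

In this assay, fluoro in place of methoxy on an aromatic carbon, para to a large group, gives a 5.0-fold lower number from compound 2 to compound 3 (0.70 log units; beyond the scatter), so this position now has a single-place comparison, and the step lies beyond the scatter. With 4-fluorophenyl held constant, bromo in place of hydrogen on an aromatic carbon gives a 1.4-fold higher number from compound 1 to compound 3 (0.15 log units; within the scatter), which lies within the scatter, so the compounds shown reveal no effect of that change in this setting. No measurement available here explains either step.

The compounds shown do not tell whether the step from methoxy to fluoro reflects the loss of methoxy or the arrival of fluoro, since neither hydrogen, chloro nor a dimethylamino group appears at this position. Going by these compounds, it also remains open whether bromo and hydrogen would again lie within the scatter alongside 4-methoxyphenyl.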